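Adding a methoxy group to compound 3: an expectation

The compounds below may be only part of what the source reports. "The series", "measured", "known", "first", "only" and "open" are said of these compounds alone.

Compound 1, `COc1ccc(CNc2nc([Se]C)nc3ccccc23)cc1`: in a functional assay on HTB-54 cells (Homo sapiens) for cytotoxicity, read by MTT assay, with a stated time of 72 h (on this read-out lower numbers stand for stronger inhibition of growth and higher numbers for weaker inhibition of growth), compound 1 gives > 100000 nM, which is a limit of the assay.
Compound 2, `CSc1nc(NCc2ccc([Se]C)cc2)c2ccccc2n1`: in this assay compound 2 gives > 100000 nM, again a limit of the assay.
Compound 3, `CSc1nc(NCc2ccccc2)c2ccccc2n1`: in this assay compound 3 gives 82300 nM.

Within the data shown here, compound 3 therefore holds the only actual number among the three; the other two sit at the limit of > 100000 nM in this assay, at which 2 of the 3 values shown sit. Among the measured compounds shown here, the one step that joins two measured compounds, an at least 1.2-fold lower number from compound 2 to compound 3 (0.08 log units; that floor lies within the scatter), takes away a methylseleno group from the benzyl ring and reaches only a floor that lies within the scatter, so it says little about size.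

Compound 4, `COc1ccc(CNc2nc(SC)nc3ccccc23)cc1`, differs from compound 3 by methoxy in place of hydrogen on an aromatic carbon. For the measured compounds named here, no measured step puts a methoxy in place of hydrogen, so none of the measured steps bears on this change directly. Going by the values given here, the only methoxy-bearing compound, compound 1, gives a limit, and it differs from compound 4 in the group on the shared core, a pair for which no step is given.

Compound 4 is thus expected to move by a 1.3-fold higher number from compound 3 to compound 4 (0.13 log units; within the scatter), a step toward a somewhat higher number, with a real chance that the assay again reports only a limit. The estimate for compound 4 is 110000 nM, with a range from 50000 nM to 250000 nM.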

Compound 4, concentration for total growth inhibition: > 100000 nM
Compound 4: no number, only a limit; the forecaster's own chance of this, stated with the estimate: 50%; the middle value lies beyond the limit too.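

Unlike the earlier compounds, this pair reads methoxy in place of hydrogen directly in this assay, giving an at least 1.2-fold higher number from compound 3 to compound 4 (0.08 log units; that floor lies within the scatter), so the change is seen only as a floor and its true size stays unknown. Among these compounds, at this position, on an aromatic carbon of the benzyl ring, compound 3 with its hydrogen still holds the only actual number, while methoxy in compound 4 and methylseleno in compound 2 both end at a limit of the assay, as does compound 1: the limit of > 100000 nM in this assay, at which 3 of the 4 values shown sit. The steps that lead to compound 4 from compound 2 and from compound 1 cannot be read, as both ends of each are limits.

The compounds shown leave open whether another group at this position, such as a fluorine atom, a hydroxyl or an amine, would give a number lower than that of compound 3. They also leave open how far past the limit compound 1, compound 2 and compound 4 lie, and so whether methoxy and methylseleno differ at all here.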